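The compounds below may be only part of what the source reports. "The series", "measured", "known", "first", "only" and "open" are said of these compounds alone.

Three compounds share one core and differ only in the aryl group hung on the saturated chain carbon bound to an oxygen on the aromatic ring. Compound 1 `O=c1cc(Cn2ccnc2)c2ccc(OCc3cc(F)cc(F)c3)cc2o1` carries a 3,5-difluorophenyl there, and in an assay on V79MZh11B1 cells for inhibition of cytochrome P450 11B1, mitochondrial (Homo sapiens), read by HPLC, with a stated time of 25 min (on this read-out higher numbers stand for weaker inhibition and lower numbers for stronger inhibition), compound 1 gives 45 nM. Compound 2 `COc1ccc(COc2ccc3c(Cn4ccnc4)cc(=O)oc3c2)cc1` carries a 4-methoxyphenyl instead, and in this assay compound 2 gives 80 nM; the change is a 1.8-fold higher number from compound 1 to compound 2 (0.25 log units; within the scatter). Compound 3 `CC(C)Oc1ccc(COc2ccc3c(Cn4ccnc4)cc(=O)oc3c2)cc1` has isopropyl in place of methyl on the oxygen on the aromatic ring, and in this assay compound 3 gives 48 nM, a move of a 1.7-fold lower number from compound 2 to compound 3 (0.22 log units; within the scatter). Compound 3 thus sits within the scatter of both neighbours, its number close to that of compound 1 and separated from compound 2 by a step that is also within the scatter.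

Compound 4 `CCCOc1ccc(COc2ccc3c(Cn4ccnc4)cc(=O)oc3c2)cc1` is the next variation: propyl in place of isopropyl on an oxygen on an aromatic ring. Among the compounds with values here, only the step from compound 2 to compound 3 touches this part of the molecule, and it stayed within the scatter; swapping one three-carbon chain for another is a smaller change still, so no step beyond the scatter in this assay is expected, in either direction. Compound 4 is therefore expected to give about 45 nM, with a range from 22 nM to 90 nM, a shift of a 1.1-fold lower number from compound 3 to compound 4 (0.03 log units; within the scatter).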

Compound 4, half-maximal inhibitory concentration: 63 nM
Compound 4: middle estimate off by 1.4-fold (0.15 log units), on the low side; measured number inside the range.
By their numbers in this assay, from the lowest: compounds 1, 3, 4 and 2 (each within the scatter of the next).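

In this assay, rearranging the same three carbons on the oxygen on the aromatic ring, from isopropyl to propyl, gives a 1.3-fold higher number from compound 3 to compound 4 (0.12 log units; within the scatter) and so the branching of this chain, now tested directly, produces no difference that can be told apart from the scatter. Growing the methyl on that oxygen into a straight propyl chain, which is ethyl in place of hydrogen on a saturated chain carbon bound to an oxygen on an aromatic ring, gives a 1.3-fold lower number from compound 2 to compound 4 (0.10 log units; within the scatter) and this step also stays within the scatter, so methyl, isopropyl and propyl on this oxygen all read alike here. Nothing available bears on the reason for these small steps.

The compounds shown leave open whether a longer chain such as hexyl, or a chain ending in an amine or a carboxylic acid, would move the number beyond the scatter. They also leave open whether propyl and isopropyl would still read alike on an aryl group that also carries fluorine.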